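Hydrazone series: aryl swap at the imine carbon

The source may report more compounds than this note shows. Statements on the series, on what has been measured and on what is new or still open speak of the compounds shown alone.

Compound 1 `COc1ccc2c(c1)CCC/C2=N\N(Cc1ccccc1)Cc1ccccc1` gives > 50000 nM, a limit of the assay.
Compound 2 `c1ccc(CN(Cc2ccccc2)/N=C2\CCCc3ccccc32)cc1` gives 25000 nM.
Compound 3 `Clc1cc(Cl)cc(/C=N/N(Cc2ccccc2)Cc2ccccc2)c1` gives > 100000 nM, a limit of the assay.

The read-out throughout is an assay on liver (Sus scrofa) for inhibition of glucose-6-phosphatase catalytic subunit 1 (Homo sapiens), using microsomes; on this read-out lower numbers stand for stronger inhibition and higher numbers for weaker inhibition. Compound 3 stands at the weak end of what is shown: its value is a limit, not a number, so it cannot be placed more closely than the limit of > 100000 nM in this assay, at which 1 of the 3 values shown sits. Compound 1 also sits at a limit, (the limit of > 50000 nM in this assay, at which 1 of the 3 values shown sits). Going by the values given here, the one step that yields a number is an at least 2.0-fold lower number from compound 1 to compound 2 (0.30 log units; that floor lies within the scatter), and it touches the fused core, not the group on the imine carbon.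

Compound 4 `OCc1ccc(/C=N/N(Cc2ccccc2)Cc2ccccc2)o1` differs from compound 3 by 5-(hydroxymethyl)furan-2-yl in place of 3,5-dichlorophenyl on a carbon with a double bond to nitrogen. No measured step alters this group, so nothing shown speaks to its effect. The step is therefore only estimated, as a number no higher from compound 3 to compound 4 (the limit leaves the size open), and the sole anchor for that estimate is that compound 3 is itself at a limit. Compound 4 is therefore expected to remain weak, estimated at 100000 nM with a range from 30000 nM to 300000 nM, most probably reported again as a limit.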

Compound 4, half-maximal inhibitory concentration: 16000 nM
For compound 4 the middle estimate is 6.3-fold (0.80 log units) above the measured one; the whole stated range lies above it.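

The group on the carbon with a double bond to nitrogen does bear on the read-out in this assay: 5-(hydroxymethyl)furan-2-yl in place of 3,5-dichlorophenyl gives an at least 6.2-fold lower number from compound 3 to compound 4 (0.79 log units; beyond the scatter), the first step shown at this position. The full size of this step stays open because the value of compound 3 is a limit: the limit of > 100000 nM in this assay, at which 1 of the 4 values shown sits.

The change swaps the ring and adds 1 hydrogen-bond donor and 2 hydrogen-bond acceptors together, and this single step does not separate these features.

Going by these compounds, it remains open whether the furan ring or the hydroxymethyl carries the change, a question that an unsubstituted furan-2-yl or a phenyl bearing hydroxymethyl would address. Also open, on these data alone, is whether the same gain would hold for a group such as a carboxylic acid at this position.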